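Isopropylcarbamoyl in place of tert-butoxycarbonyl on the shared core

This account rests on a few compounds, and the source may have more. Where it says the series, first, only, none or still open, it means among the compounds named here.

Three compounds have been run in an ADME assay on microsomes from liver (Homo sapiens) for metabolic stability, with a stated time of 10 min; a higher number here means that more of the compound is left, a lower number that less of the compound is left:
Compound 1, `CC(C)(C)OC(=O)NCCS(=O)(=O)NC(=O)c1ccc(Nc2nc(NC3(c4ccc(Cl)cc4)CC3)nc(OCC(F)(F)F)n2)cc1`, gives 92%.
Compound 2, `CCS(=O)(=O)NC(=O)c1ccc(Nc2nc(NC3(c4ccc(Cl)cc4)CC3)nc(OCC(F)(F)F)n2)cc1`, gives 100%.
Compound 3, `O=C(NS(=O)(=O)c1ccccc1)c1ccc(Nc2nc(NC3(c4ccc(Cl)cc4)CC3)nc(OCC(F)(F)F)n2)cc1`, gives 100%.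

Compound 1 holds the lowest of the three numbers in this assay, yet both gaps lie within the scatter: a number 8 percentage points higher from compound 1 to compound 2 (within the scatter) and a number 8 percentage points higher from compound 1 to compound 3 (within the scatter). Between the two larger values there is no change at the digits printed from compound 2 to compound 3 (within the scatter). Across these three, whatever sits on the sulfonyl sulfur has not moved the read-out beyond the scatter.

Compound 4, `CC(C)NC(=O)NCCS(=O)(=O)NC(=O)c1ccc(Nc2nc(NC3(c4ccc(Cl)cc4)CC3)nc(OCC(F)(F)F)n2)cc1`, differs from compound 1 by isopropylamino in place of tert-butoxy on a carbonyl carbon. Going by the values given here, the steps that bear on this change are those that remove the whole 2-((tert-butoxycarbonyl)amino)ethyl arm or the (tert-butoxycarbonyl)amino group from compound 1, both within the scatter. Compound 4 keeps the chain and only swaps the end group, so no step beyond the scatter is expected: a number 2 percentage points lower from compound 1 to compound 4 (within the scatter). Compound 4 is therefore estimated at 90%, in a range from 75% to 100%.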

Compound 4, percent of the compound remaining: 100%
Compound 4: the middle estimate sits 10 percentage points below what was measured; the measured number falls inside the stated range.
By their numbers in this assay, from the lowest: compounds 1, 2, 3 and 4 (each within the scatter of the next).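

In this assay, isopropylamino in place of tert-butoxy on a carbonyl carbon stays inside the scatter (a number 8 percentage points higher from compound 1 to compound 4 (within the scatter)), so this end group can be exchanged without a readable step. The 2-((isopropylcarbamoyl)amino)ethyl arm on the sulfonyl sulfur reads level with phenyl (no change at the digits printed from compound 3 to compound 4 (within the scatter)), and (isopropylcarbamoyl)amino on the saturated chain carbon reads level with hydrogen (no change at the digits printed from compound 2 to compound 4 (within the scatter)), which extends the flat picture on the sulfonyl sulfur to a second arm bearing a chain. No measurement at hand bears on the reason for these readings.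

Open, as far as these compounds go, is whether an amine or a carboxylic acid in place of (isopropylcarbamoyl)amino, or a longer chain on the sulfonyl sulfur, would give a step beyond the scatter. With every step among compound 1, compound 2, compound 3 and compound 4 inside the scatter, these groups cannot be ranked.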